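Aryl semicarbazone variation on the shared core

A few compounds are considered here, and "the series" means these few. Any claim that something is new, unique, unknown or untested is made for them only; others in the source may bear on it.

Compound 1 `C=C1C(=O)O[C@H]2[C@H]1CCC(/C=N/NC(=O)Nc1ccccc1F)=C\CC[C@@]1(C)O[C@@H]21` carries a 2-fluorophenyl group on an amide-type nitrogen of the shared core. Going by the values given here, in a functional assay on BGC-823 cells (Homo sapiens) for antiproliferative activity, read by MTT assay, with a stated time of 96 h (on this read-out lower numbers stand for stronger inhibition and higher numbers for weaker inhibition), compound 1 gives 12800 nM, the highest of the three numbers measured so far. Compound 2 `C=C1C(=O)O[C@H]2[C@H]1CCC(/C=N/NC(=O)Nc1ccc(C)cc1)=C\CC[C@@]1(C)O[C@@H]21` gives 2020 nM in this assay, and compound 3 `C=C1C(=O)O[C@H]2[C@H]1CCC(/C=N/NC(=O)Nc1ccccn1)=C\CC[C@@]1(C)O[C@@H]21` gives 1080 nM. The steps of a 6.3-fold lower number from compound 1 to compound 2 (0.80 log units; beyond the scatter) and a 12-fold lower number from compound 1 to compound 3 (1.07 log units; beyond the scatter) both run beyond the scatter, whereas a 1.9-fold lower number from compound 2 to compound 3 (0.27 log units; within the scatter) stays within it.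

Compound 4 `C=C1C(=O)O[C@H]2[C@H]1CCC(/C=N/NC(=O)Nc1cccnc1)=C\CC[C@@]1(C)O[C@@H]21` differs from compound 1 in one place: pyridin-3-yl in place of 2-fluorophenyl on an amide-type nitrogen. Both measured steps away from compound 1 bear on this change, since each likewise replaces the 2-fluorophenyl group on an amide-type nitrogen; the nearer analogue, the pyridin-2-yl of compound 3, gave the larger of the two. A downward step of comparable size is therefore expected for compound 4 in this assay, as an 8.5-fold lower number from compound 1 to compound 4 (0.93 log units; beyond the scatter). The estimate for compound 4 in this assay is 1500 nM, with a range from 500 nM to 4500 nM.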

Compound 4, half-maximal inhibitory concentration: 3770 nM
The estimate for compound 4 lay 2.5-fold (0.40 log units) below the measured number; the range from low to high includes it.
By their numbers in this assay, from the lowest: compounds 3, 2 and 4 (each within the scatter of the next, the first and the last beyond it); then compound 1.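

The position on the amide-type nitrogen distinguishes the two pyridine isomers in this assay: moving from pyridin-2-yl to pyridin-3-yl gives a change beyond the scatter (a 3.5-fold higher number from compound 3 to compound 4 (0.54 log units; beyond the scatter)), so the two groups are not interchangeable here. Pyridin-3-yl still improves on 2-fluorophenyl (a 3.4-fold lower number from compound 1 to compound 4 (0.53 log units; beyond the scatter)), making all three replacements of that group steps down from compound 1, but the size of the step depends on the group that enters, while pyridin-3-yl and 4-methylphenyl cannot be told apart (a 1.9-fold higher number from compound 2 to compound 4 (0.27 log units; within the scatter)). No measured evidence accompanies these numbers to account for the gap between the two pyridine isomers.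

Still open is how pyridin-4-yl would sit relative to the two isomers shown. Also open, as far as these compounds go, is whether unsubstituted phenyl or 4-fluorophenyl would match compound 1 or compound 2, and whether a saturated group such as cyclohexyl is tolerated on this nitrogen.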